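The source may hold more compounds than are shown below. What is called first, only, known or untested is meant among the compounds shown, and "the series" means these compounds.

Compound 1 `COc1cc2nnc(C(N)=O)c(Nc3ccc(C)cc3F)c2cc1N1CCN(C(C)C)CC1`: 2.5 h
Compound 2 `COc1cc2nnc(C(N)=O)c(Nc3ccc(C)cc3F)c2cc1N1CCC(N(C)C)CC1`: 0.9 h

Both numbers come from an ADME assay on the whole organism for metabolic stability, with Rattus norvegicus as the target; on this read-out higher numbers stand for a longer-lived compound and lower numbers for a shorter-lived compound. For the measured compounds named here, compound 2 stands lowest of the two measured; the only measured step is a 2.8-fold lower number from compound 1 to compound 2 (0.44 log units; beyond the scatter). Compound 3 `COc1cc2nnc(C(N)=O)c(Nc3ccc(C)cc3F)c2cc1N1CCC(OC)CC1` carries the change (methoxy in place of dimethylamino on a saturated ring carbon). Going by the values given here, that single step swaps an entire ring on the aromatic carbon and does not isolate methoxy against dimethylamino, so no direct precedent exists for this change. The step from compound 2 to compound 3 is therefore expected to be small, a 1.6-fold higher number from compound 2 to compound 3 (0.19 log units; within the scatter), with no firm direction. Compound 3 is estimated at 1.4 h in this assay, range 0.6 h to 3.5 h.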

Compound 3, half-life in the Rattus norvegicus assay: 0.6 h
Compound 3: the middle estimate sits 2.3-fold (0.37 log units) above what was measured; measured number inside the range.
By their numbers in the Rattus norvegicus assay, from the lowest: compounds 3 and 2 (each within the scatter of the next); then compound 1.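

In the Rattus norvegicus assay, the isolated swap of dimethylamino for methoxy on the saturated ring carbon gives a 1.5-fold lower number from compound 2 to compound 3 (0.18 log units; within the scatter), so half-life does not separate these two groups at this position. The larger replacement on the aromatic carbon, 4-methoxypiperidin-1-yl for 4-isopropylpiperazin-1-yl, gives a 4.2-fold lower number from compound 1 to compound 3 (0.62 log units; beyond the scatter). In a physicochemical assay for solubility (a higher number here means a more soluble compound, a lower number a less soluble compound), compound 2 gives 340000 nM and compound 3 gives 2000 nM, so the two stand far apart on this read-out despite their matching half-lives.

Open, from the compounds shown here alone, is whether hydroxy, a primary amine or a longer ether chain on this ring carbon would combine the solubility of compound 2 with the half-life of compound 1.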